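Swapping the carbamate cap for an oxadiazole arm

This account rests on a few compounds, and the source may have more. Where it says the series, first, only, none or still open, it means among the compounds named here.

Compounds measured so far:
compound 1, `CC(C)(C)OC(=O)N1CCC(O[C@H]2CC[C@H](Oc3ccc(S(C)(=O)=O)cn3)CC2)CC1`: 47 nM
compound 2, `CC(C)S(=O)(=O)c1cnc(O[C@H]2CC[C@H](OC3CCN(C(=O)OC(C)(C)C)CC3)CC2)cn1`: 18.5 nM
compound 3, `C[C@@H](CF)OC(=O)N1CCC(O[C@H]2CC[C@H](Oc3cnc(S(C)(=O)=O)cn3)CC2)CC1`: 31.1 nM

All three were tested in a functional assay on isolated protein for agonist activity at Glucose-dependent insulinotropic receptor (Homo sapiens), read by HTRF and cAMP accumulation; on this read-out lower numbers stand for an effect already at smaller amounts and higher numbers for an effect only at larger amounts of compound. Compound 3 sits second highest of the three numbers; its gap to compound 1 and its gap to compound 2 both fall within the scatter, so the three cannot be ordered with confidence.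

Compound 4, `CC(F)Cc1nc(CN2CCC(O[C@H]3CC[C@H](Oc4cnc(S(C)(=O)=O)cn4)CC3)CC2)no1`, has not yet been measured. It differs from compound 3 in one place: a group of 10 heavy atoms (6 carbon, 2 nitrogen, 1 oxygen, 1 fluorine; one five-membered aromatic ring with 3 hetero atoms) in place of a group of 7 heavy atoms (4 carbon, 2 oxygen, 1 fluorine; no ring), on an amine nitrogen in a ring. Among the compounds with values here, no measured pair shows a change of this kind, so there is no comparable step to lean on.

The step from compound 3 to compound 4 is expected to be a 1.6-fold higher number from compound 3 to compound 4 (0.21 log units; within the scatter), within the scatter or modestly upward. Compound 4 is estimated at 50 nM, with a range of 12 nM to 200 nM.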

Compound 4, half-maximal effective concentration: 30.3 nM
The estimate for compound 4 lay 1.7-fold (0.22 log units) above the measured number, within the range that was stated.
By their numbers in this assay, from the lowest: compounds 2, 4, 3 and 1 (each within the scatter of the next, the first and the last beyond it).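

On the amine nitrogen in the ring, the (5-(2-fluoropropyl)-1,2,4-oxadiazol-3-yl)methyl group can replace the carbamate cap while this assay shows a 1.0-fold lower number from compound 3 to compound 4 (0.01 log units; within the scatter). Within the data shown here, this position therefore accepts a group with a five-membered aromatic ring as well as one with no ring, which the earlier compounds did not show. Nothing available gives a reason for this match.

Still open, as far as these compounds go, is how the oxadiazole arm reads with a plain propyl chain, without the fluorine, or with a longer chain. The compounds shown also leave open what a phenyl ring would do in place of the oxadiazole.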